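The compounds below may be only part of what the source reports. "The series", "measured", "known", "first", "only" and "open" are said of these compounds alone.

Compound 1 `Cc1ccccc1N1CCN(C(=S)SCc2ccc3nc(N)nc(N)c3c2)CC1`: "not determined" (no result reported)
Compound 2 `Nc1nc(N)c2cc(CSC(=S)N3CCN(c4ccccc4Cl)CC3)ccc2n1`: 4050 nM
Compound 3 `Nc1nc(N)c2cc(CSC(=S)N3CCN(c4ccc(Cl)c(Cl)c4)CC3)ccc2n1`: 3060 nM

These three compounds were tested in a functional assay on HeLa cells (Homo sapiens) for antiproliferative activity, read by MTT assay, with a stated time of 72 h; on this read-out higher numbers stand for weaker inhibition and lower numbers for stronger inhibition. Within the data shown here, only two gave a number, and compound 3 at 3060 nM lies within the usual scatter of compound 2 at 4050 nM. Neither can be ranked above the other, and compound 1 offers no comparison.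

The next compound to be tested is compound 4 `Nc1nc(N)c2cc(CSC(=S)N3CCN(c4ccc([N+](=O)[O-])cc4)CC3)ccc2n1`. It keeps the shared core and changes one group, on an amine nitrogen in a ring: 4-nitrophenyl in place of 3,4-dichlorophenyl on an amine nitrogen in a ring.

Among the measured compounds shown here, only one measured step bears on this change. It is a 1.3-fold lower number from compound 2 to compound 3 (0.12 log units; within the scatter), made at the same place, and it stays within the scatter. For the measured compounds named here, that step swapped one chlorinated phenyl group for another, whereas no measured compound carries the 4-nitrophenyl group, so it is a limited guide. With so little evidence, no shift beyond the scatter is expected in this assay, and no direction can be argued with confidence. The expected change is a 1.1-fold higher number from compound 3 to compound 4 (0.06 log units; within the scatter), a small step that leaves room for surprise.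

For compound 4 the estimated value is 3500 nM, with an expected range from 1500 nM to 8000 nM.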

Compound 4, half-maximal inhibitory concentration: 1660 nM
Estimate against measurement, compound 4: 2.1-fold (0.32 log units) above, within the range that was stated.
By their numbers in this assay, from the lowest: compounds 4, 3 and 2 (each within the scatter of the next, the first and the last beyond it).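

In this assay, among these compounds, the group on the amine nitrogen in a ring now proves able to move the number: a 2.4-fold lower number from compound 2 to compound 4 (0.39 log units; beyond the scatter) is the first step at this place to pass beyond the scatter, though only modestly. That step compares 4-nitrophenyl with 2-chlorophenyl, while a 1.8-fold lower number from compound 3 to compound 4 (0.27 log units; within the scatter) stays within the scatter, so the 4-nitrophenyl and 3,4-dichlorophenyl groups cannot be ranked against each other, and the chlorinated phenyl groups are shown to be no requirement for activity at this level in these three compounds. No measurement shown here accounts for this difference between the groups.

Among the compounds shown here, compound 1 has no number, so its 2-methylphenyl group cannot yet be placed among the others, and the comparison still rests on only three values, all from a single cell assay. As far as these compounds go, what a plain phenyl, a 4-chlorophenyl or a 4-aminophenyl group would give at this place stays open, and any of these would help show whether the difference between compound 2 and compound 4 belongs to the nitro group or to where the group sits on the phenyl ring.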